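Extending the piperazine of compound 3 toward compound 4

The source may report more compounds than this note shows. Statements on the series, on what has been measured and on what is new or still open speak of the compounds shown alone.

Compound 3 `CN1CCN(CC(=O)Nc2ccc(-c3nc(-c4ccccc4)c(-c4ccccc4)n3C)cc2)CC1` stands highest of the three compounds measured in a functional assay on HT-29 cells (Homo sapiens) for cytotoxicity, read by MTT assay, with a stated time of 24 h, tested at 1.6 ug/mL; on this read-out lower numbers stand for a weaker effect and higher numbers for a stronger effect at the one concentration tested: compound 3 gives 27.4%, whereas compound 1 `Cc1ccc2oc(SCC(=O)Nc3ccc(-c4nc(-c5ccccc5)c(-c5ccccc5)n4C)cc3)nc2c1` gives 15.5% and compound 2 `Cn1c(-c2ccc(NC(=O)CSc3nc4ccccc4s3)cc2)nc(-c2ccccc2)c1-c1ccccc1` gives 15.3%. The two steps that reach compound 3 are a number 11.9 percentage points higher from compound 1 to compound 3 (beyond the scatter) and a number 12.1 percentage points higher from compound 2 to compound 3 (beyond the scatter), while a number 0.2 percentage points lower from compound 1 to compound 2 (within the scatter). Compound 4 `COc1ccc(CN2CCN(CC(=O)Nc3ccc(-c4nc(-c5ccccc5)c(-c5ccccc5)n4C)cc3)CC2)cc1` differs from compound 3 by 4-methoxyphenyl in place of hydrogen on a saturated chain carbon bound to an amine nitrogen in a ring. Among the measured compounds shown here, no measured step bears on this change; the steps to compound 3 concern the exchange of the whole sulfanyl group for 4-methylpiperazin-1-yl, not any change on that ring. An estimate for compound 4 therefore rests on compound 3 alone, with a step of a number 1.6 percentage points higher from compound 3 to compound 4 (within the scatter) expected to stay within the scatter. Compound 4 is thus expected to give 29%, between 12% and 50%.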

Compound 4, a percentage reported as activity, at one concentration (the size of the read-out at that concentration, not a potency): 10.1%
Beside the measured number, compound 4's estimate is 18.9 percentage points above it, and the stated range ends above it.
By their numbers in this assay, from the lowest: compounds 4, 2 and 1 (each within the scatter of the next); then compound 3.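

Read as methyl to 4-methoxybenzyl, this change gives a number 17.3 percentage points lower from compound 3 to compound 4 (beyond the scatter) in this assay, the first reading for a substituent on a saturated chain carbon bound to an amine nitrogen in a ring. Among the compounds shown here, it shows that this place is not indifferent to what it carries, which the earlier compounds could not show, as their steps concerned only the exchange of the whole sulfanyl group. Nothing available here accounts for the size of this step. From the compounds shown here alone, whether the loss belongs to the methoxy group or to the ring itself stays open, and an unsubstituted benzyl or an ethyl group at this place would bear on that.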